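This account rests on a few compounds, and the source may have more. Where it says the series, first, only, none or still open, it means among the compounds named here.

Measured in an assay on isolated protein (Mus musculus) for inhibition of IL15-IL15 receptor (Homo sapiens), read by resazurin assay, with stated times of 30 min and 2.5 days; on this read-out lower numbers stand for stronger inhibition and higher numbers for weaker inhibition:
- compound 1, `COc1ccc(NC(=O)CCCCCCCSc2nnc(Cc3nn(C)c(=O)c4ccccc34)n2C)cc1`, gives 3900 nM
- compound 2, `Cn1c(Cc2nn(C)c(=O)c3ccccc23)nnc1SCCCCCCCCCCC(=O)Nc1ccccc1Cl`, gives 15000 nM
- compound 3, `Cn1c(Cc2nn(C)c(=O)c3ccccc23)nnc1S(=O)(=O)CCCCCCCC(=O)Nc1ccc(Br)cc1Br`, gives 1400 nM

Among these three numbers compound 1 stands second highest. Its nearest neighbour is compound 3, whose number lies lower by a margin beyond the usual scatter, and the furthest is compound 2, whose number lies higher, again beyond the scatter. All three share the same core and differ in the chain, in the sulfur-bearing link and in the group on the amide-type nitrogen, so no single change among the measured compounds can be read on its own.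

The step considered here leads from compound 1 to compound 4, `Cc1ccc(NC(=O)CCCCCCCSc2nnc(Cc3nn(C)c(=O)c4ccccc34)n2C)c(Cl)c1`, which has not yet been measured in this assay. The change is 2-chloro-4-methylphenyl in place of 4-methoxyphenyl on an amide-type nitrogen. Within the data shown here, no measured pair shows this change by itself, so the account rests on the three values alone. Since nothing among them singles out the group on the amide-type nitrogen, the step from compound 1 to compound 4 is expected to be small, a 1.0-fold higher number from compound 1 to compound 4 (0.01 log units; within the scatter), in no clear direction and within the scatter. Compound 4 is therefore estimated at 4000 nM, with a range from 1300 nM to 12000 nM.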

Compound 4, half-maximal inhibitory concentration: 2300 nM
Estimate against measurement, compound 4: 1.7-fold (0.24 log units) above, within the range that was stated.
By their numbers in this assay, from the lowest: compounds 3, 4 and 1 (each within the scatter of the next, the first and the last beyond it); then compound 2.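

In this assay, among these compounds, the group on the amide-type nitrogen can now be read on its own for the first time: with the chain, the sulfur-bearing link and the shared core held fixed, 2-chloro-4-methylphenyl in place of 4-methoxyphenyl gives a 1.7-fold lower number from compound 1 to compound 4 (0.23 log units; within the scatter). This exchange removes the oxygen and its hydrogen-bond acceptor and brings in a chlorine while keeping the count of heavy atoms, yet it leaves the read-out within the usual scatter, so in this pair the position accepts both aryl groups without a clear difference. Nothing given here accounts for that outcome.

This single pair does not separate the part played by the chlorine from that of the methyl in 2-chloro-4-methylphenyl, and it leaves open whether an unsubstituted phenyl, or a carboxylic acid or a dimethylamino group on the phenyl ring, would be accepted equally well. From the compounds shown here alone, the steps linking compound 2 and compound 3 to the other compounds cannot be read, as each of those pairs differs in more than one place, so it also stays open whether this result holds with a longer chain or a sulfonyl link.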